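From 4-methylpiperazin-1-yl to 4-ethylpiperazin-1-yl at the assay limit

The compounds below may be only part of what the source reports. "The series", "measured", "known", "first", "only" and "open" are said of these compounds alone.

Measured so far in an ADME assay on microsomes from liver (Mus musculus) for metabolic stability, read by LC-MS, using NADPH, with stated times of 15 min and 60 min, tested at 4.6 uM; a lower number here means that the compound disappears faster, a higher number that the compound lasts longer:
- Compound 1 `CN1CCN(c2ccc3c(c2)oc(=O)n3C(=O)NCCCCc2ccccc2)C(=O)C1`: < 0.0834 h (a limit)
- Compound 2 `CN1CCN(c2ccc3c(c2)oc(=O)n3C(=O)NCCCCc2ccccc2)CC1`: < 0.0834 h (a limit)

Compound 2 stands at < 0.0834 h, which is a limit of the assay and not a number. Among the compounds with values here, the same holds for the only other compound measured, as the data show (the limit of < 0.0834 h in this assay, at which 2 of the 2 values shown sit).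

Compound 3 `CCN1CCN(c2ccc3c(c2)oc(=O)n3C(=O)NCCCCc2ccccc2)CC1` has not yet been measured. It differs from compound 2 by methyl in place of hydrogen on a saturated chain carbon bound to an amine nitrogen in a ring, which turns 4-methylpiperazin-1-yl into 4-ethylpiperazin-1-yl.

Within the data shown here, the only measured step that bears on this is a step that the two limits leave unreadable from compound 1 to compound 2, so it offers no size to carry over. It comes from a different change, too. No step beyond the scatter is therefore expected in this assay, in either direction. The estimated step is a step that the limit leaves unreadable from compound 2 to compound 3. Another limit is the likeliest report. Compound 3 is estimated at 0.08 h, with an expected range of 0.05 h to 0.14 h.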

Compound 3, half-life: < 0.0834 h
Compound 3 was reported as a limit (the forecaster's own chance of this, stated with the estimate: 85%); the middle value lies beyond the limit too.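

Compound 1, compound 2 and compound 3 all end at the same limit, so no step among them can be read: the limit of < 0.0834 h in this assay, at which 3 of the 3 values shown sit.

The compounds shown leave open the actual half-life of each one, and whether changing 4-methylpiperazin-1-yl to 4-ethylpiperazin-1-yl alters it at all.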